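Changing the aryl group on compound 2

The source may report more compounds than this note shows. Statements on the series, on what has been measured and on what is new or still open speak of the compounds shown alone.

In a functional assay on HeLa cells (Homo sapiens) for antiproliferative activity, read by spectrophotometry, with a stated time of 2 days (on this read-out higher numbers stand for weaker inhibition of growth and lower numbers for stronger inhibition of growth), compound 2 `Cc1ccc(Nc2ncc(C(F)(F)F)c(N3Cc4cccc(N(C)S(C)(=O)=O)c4C3)n2)c(Cl)c1` gives 10900 nM. Compound 3 `CN(c1cccc2c1CN(c1nc(Nc3ccc(Nc4ccccc4)cc3)ncc1C(F)(F)F)C2)S(C)(=O)=O` gives 7300 nM, within the scatter of that value, so the two stand together at the high end of the three numbers. Compound 1 `COc1cc(N2CCN(C(C)=O)CC2)ccc1Nc1ncc(C(F)(F)F)c(N2Cc3cccc(N(C)S(C)(=O)=O)c3C2)n1` gives 1300 nM, a lower number, and its gap to compound 2 lies beyond the scatter. Compound 4 `COc1cc(Nc2ncc(C(F)(F)F)c(N3Cc4cccc(N(C)S(C)(=O)=O)c4C3)n2)cc(OC)c1` is still unmeasured, and its change is 3,5-dimethoxyphenyl in place of 2-chloro-4-methylphenyl on a nitrogen on an aromatic ring. Going by the values given here, no two measured compounds differ in one place only, so there is no direct guide. The expected change is a 1.8-fold lower number from compound 2 to compound 4 (0.26 log units; within the scatter), a modest move towards stronger inhibition that may stay within the scatter. For compound 4 the estimated value is 6000 nM, with an expected range from 2000 nM to 18000 nM.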

Compound 4, concentration for 50% growth inhibition: 7000 nM
Compound 4: the middle estimate sits 1.2-fold (0.07 log units) below what was measured, within the range that was stated.
By their numbers in this assay, from the lowest: compound 1; then compounds 4, 3 and 2 (each within the scatter of the next).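

In this assay, going by these compounds alone, replacing 2-chloro-4-methylphenyl with 3,5-dimethoxyphenyl on this nitrogen gives a 1.6-fold lower number from compound 2 to compound 4 (0.19 log units; within the scatter) and is the first step here that reads one change directly. The swap removes the chlorine and brings in two hydrogen-bond acceptors, yet it does not separate the two compounds on this read-out. No measurement shown here bears on why the number holds.

Still open, on these data alone, is whether a carboxylic acid or a free amine on this aryl ring would move the number beyond the scatter.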